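Trifluoromethyl in Place of Chloro: What to Expect for Compound 4

The source may hold more compounds than are shown below. What is called first, only, known or untested is meant among the compounds shown, and "the series" means these compounds.

Three compounds have been measured in an ADME assay on HaCaT cells (Homo sapiens) for antiproliferative activity, read by MTT assay, with a stated time of 48 h; a higher number here means a weaker inhibitor, a lower number a stronger inhibitor:
Compound 1, `O=C(/C=C\Nc1ccc(C(F)(F)F)cc1)c1cn(-c2ccccc2)nc1-c1ccccc1`, gives > 50000 nM.
Compound 2, `O=C(/C=C\Nc1ccc(F)cc1)c1cn(-c2ccccc2)nc1-c1ccc(F)cc1`, gives > 50000 nM.
Compound 3, `O=C(/C=C\Nc1ccc(Cl)cc1)c1cn(-c2ccccc2)nc1-c1ccc(F)cc1`, gives 21300 nM.

The value of compound 1 is a limit of the assay, not a number. The value of compound 2 is likewise a limit. Going by the values given here, compound 3 is therefore the only compound with a number; the other two sit at a limit. Among the compounds with values here, the single measured step is an at least 2.3-fold lower number from compound 2 to compound 3 (0.37 log units; beyond the scatter).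

Compound 4, `O=C(/C=C\Nc1ccc(C(F)(F)F)cc1)c1cn(-c2ccccc2)nc1-c1ccc(F)cc1`, is not yet measured. It differs from compound 3 by trifluoromethyl in place of chloro on an aromatic carbon. Within the data shown here, no measured step covers this change; compound 1 also carries the trifluoromethyl and sits at the limit. Because (the limit of > 50000 nM in this assay, at which 2 of the 3 values shown sit), a weak inhibitor is expected. Compound 4 is expected to give 40000 nM (range 15000 nM to 120000 nM). The expected step is a 1.9-fold higher number from compound 3 to compound 4 (0.27 log units; within the scatter).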

Compound 4, half-maximal inhibitory concentration: > 50000 nM
Compound 4 was reported as a limit (the forecaster's own chance of this, stated with the estimate: 55%); middle value at least 1.2-fold (0.09 log units) away from the limit.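

On this aromatic carbon, trifluoromethyl in place of chloro gives an at least 2.3-fold higher number from compound 3 to compound 4 (0.37 log units; beyond the scatter). Chloro in compound 3 thus remains the only group at this position that gives a number, while fluoro in compound 2 and trifluoromethyl in compound 4 both end at a limit of the assay, and the steps to compound 4 from compound 2 and from compound 1 cannot be read. The limit now holds most of the series: the limit of > 50000 nM in this assay, at which 3 of the 4 values shown sit.

Left open is how far past the limit compound 2 and compound 4 lie. Also open, going by these compounds, is whether an amine or a methoxy group at this position would give a number.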